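Adding a Methoxy Group to a Weakly Cytotoxic Core

This account rests on a few compounds, and the source may have more. Where it says the series, first, only, none or still open, it means among the compounds named here.

Compound 3 `CN1CC(=O)Nc2cnc(Nc3ccccc3)nc21` was tested in a functional assay on MDA-MB-231 cells (Homo sapiens) for cytotoxicity, read by MTT assay, with a stated time of 48 h; a higher number here means a weaker inhibitor, a lower number a stronger inhibitor. There compound 3 gives > 100000 nM, which is a limit of the assay and not a number. Compound 1 `O=C1CNc2nc(Nc3ccccc3)ncc2N1` in this assay gives > 100000 nM, likewise a limit. Compound 2 `COc1cccc(Nc2ncc3c(n2)NCC(=O)N3)c1` gives 93200 nM. The step from compound 1 to compound 2 was an at least 1.0-fold lower number from compound 1 to compound 2 (0.03 log units; that floor lies within the scatter), and the step from compound 1 to compound 3 was a step that the two limits leave unreadable from compound 1 to compound 3 since (the limit of > 100000 nM in this assay, at which 2 of the 3 values shown sit). Compound 4 `COc1cccc(Nc2ncc3c(n2)N(C)CC(=O)N3)c1` differs from compound 3 by methoxy in place of hydrogen on an aromatic carbon, the same change as from compound 1 to compound 2. That earlier step showed no shift beyond the scatter, so for compound 4 a step of a number no higher from compound 3 to compound 4 (the limit leaves the size open) is expected. Compound 4 is therefore estimated at 100000 nM, between 40000 nM and 250000 nM.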

Compound 4, half-maximal inhibitory concentration: > 100000 nM
Compound 4 ended at the assay's limit (the forecaster's own chance of this, stated with the estimate: 70%); the middle value lies on the limit itself.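

Methoxy in place of hydrogen on an aromatic carbon has now been tried on the core with the added methyl, and the step it gives there, like every step with a limit at both ends, cannot be read: the limit of > 100000 nM in this assay, at which 3 of the 4 values shown sit.

Among the compounds shown here, the one readable new step is an at least 1.0-fold higher number from compound 2 to compound 4 (0.03 log units; that floor lies within the scatter), for methyl in place of hydrogen on a nitrogen. On these data alone, it gives only a floor, so the true size of this step stays unknown.

As far as these compounds go, it remains open whether an amine or a carboxylic acid at this place on the ring would bring compound 4's core to a value that can be read in this assay.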